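A Furan Ester Replaces the Trifluoromethylphenyl Ester

This account rests on a few compounds, and the source may have more. Where it says the series, first, only, none or still open, it means among the compounds named here.

Compound 1 `CC1=CC[C@H]2[C@@H]1CC=C(C)[C@@H](CC[C@H]1[C@]3(C)CC[C@H](O)C(C)(C)O[C@H]3CC[C@@]1(C)O)C2(C)C` — > 50000 nM
Compound 2 `CC1=CC[C@H]2[C@H](CC[C@]2(C)O)C(C)(C)[C@@H]1CC[C@H]1[C@]2(C)CC[C@H](OC(=O)c3ccc(C(F)(F)F)cc3)C(C)(C)O[C@H]2CC[C@@]1(C)O` — 19500 nM

Of the compounds shown here, two have been tested in a functional assay on MDA-MB-231 cells (Homo sapiens) for antiproliferative activity, read by MTT assay, with a stated time of 72 h; on this read-out higher numbers stand for weaker inhibition and lower numbers for stronger inhibition. For compound 1 the result is only a limit of the assay, > 50000 nM. Among the measured compounds shown here, compound 2 gives 19500 nM, the only definite number available. The other entry is the limit of > 50000 nM in this assay, at which 1 of the 2 values shown sits. Compound 3 `CC1=CC[C@H]2[C@H](CC[C@]2(C)O)C(C)(C)[C@@H]1CC[C@H]1[C@]2(C)CC[C@H](OC(=O)c3ccco3)C(C)(C)O[C@H]2CC[C@@]1(C)O` has not yet been measured in this assay . It differs from compound 2 by furan-2-yl in place of 4-(trifluoromethyl)phenyl on a carbonyl carbon. For the measured compounds named here, no step between measured compounds is known, so nothing measured here tells how this exchange acts. Since the ester is kept and only the aromatic group attached to the carbonyl carbon changes, a step of small to moderate size is expected, in either direction, and possibly not beyond the usual scatter. Compound 3 is therefore estimated at about 25000 nM, with a range from 8000 nM to 80000 nM. This corresponds to an expected step of a 1.3-fold higher number from compound 2 to compound 3 (0.11 log units; within the scatter).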

Compound 3, half-maximal inhibitory concentration: 14000 nM
Compound 3: middle estimate off by 1.8-fold (0.25 log units), on the high side; the range from low to high includes it.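

In this assay, furan-2-yl in place of 4-(trifluoromethyl)phenyl on a carbonyl carbon gives a 1.4-fold lower number from compound 2 to compound 3 (0.14 log units; within the scatter). Among the compounds shown here, this is the first step that can be read at this position, and it shows that one five-membered aromatic ring with 1 hetero atom and one six-membered aromatic ring of carbon only cannot be told apart on this read-out, with the ester kept. Nothing shown gives a reason for this outcome.

The compounds shown leave open whether this position responds at all to the group carried on the carbonyl carbon, since this single step lies within the scatter. An open-chain group such as hexanoyl, or a pyridine ring or an aminophenyl group in place of furan-2-yl, could still show whether a larger step is possible here.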